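Demethylation of the methoxy group: compound 3 to compound 4

A few compounds are considered here, and "the series" means these few. Any claim that something is new, unique, unknown or untested is made for them only; others in the source may bear on it.

Going by the values given here, compound 3 `COc1cccc(-c2nc3sccn3c2-c2ccnc(NCCNC(=O)Nc3cccc(C(F)(F)F)c3)n2)c1` gives 5300 nM in a functional assay on A375P cells (Homo sapiens) for antiproliferative activity, read by MTT assay, with a stated time of 48 h (on this read-out higher numbers stand for weaker inhibition and lower numbers for stronger inhibition), the only number in the set so far. Compound 1 `O=C(NCCNc1nccc(-c2c(-c3cccc(O)c3)nc3sccn23)n1)Nc1ccccc1` reaches only the limit > 10000 nM in this assay. Compound 2 `COc1cccc(-c2nc3sccn3c2-c2ccnc(NCCNC(=O)Nc3ccccc3)n2)c1` likewise sits at the limit > 10000 nM in this assay. The trifluoromethyl change brought an at least 1.8-fold lower number from compound 2 to compound 3 (0.27 log units; that floor lies within the scatter), a floor that lies within the scatter.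

Compound 4 `O=C(NCCNc1nccc(-c2c(-c3cccc(O)c3)nc3sccn23)n1)Nc1cccc(C(F)(F)F)c1` differs from compound 3 by hydrogen in place of methyl on an oxygen on an aromatic ring. Among the compounds with values here, the one measured step of this kind, a step that the two limits leave unreadable from compound 1 to compound 2, runs in the opposite direction and has no readable size because both of its values sit at the limit of > 10000 nM in this assay, at which 2 of the 3 values shown sit. Nothing in the set therefore points to a shift in either direction.

For compound 4 the step of a 1.2-fold higher number from compound 3 to compound 4 (0.09 log units; within the scatter) is expected, within the scatter. Compound 4 is estimated at 6500 nM, between 2500 nM and 20000 nM, with a fair chance that this assay reports only a limit for compound 4.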

Compound 4, half-maximal inhibitory concentration: 4200 nM
For compound 4 the middle estimate is 1.5-fold (0.19 log units) above the measured one; the range from low to high includes it.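

In this assay the change from methoxy to hydroxy now has a readable size, a 1.3-fold lower number from compound 3 to compound 4 (0.10 log units; within the scatter), so with trifluoromethyl in place the two groups cannot be told apart at this position. The trifluoromethyl change, by contrast, gives its first step beyond the scatter on the hydroxy side, an at least 2.3-fold lower number from compound 1 to compound 4 (0.37 log units; beyond the scatter), although the start of that step is a limit and not a number. That change can now be read on two cores, with the same direction so far as the limits allow: the same change on two cores in this assay, an at least 1.8-fold lower number (0.27 log units; that floor lies within the scatter) from compound 2 to compound 3 and an at least 2.3-fold lower number (0.37 log units; beyond the scatter) from compound 1 to compound 4; the limit leaves it open whether they differ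

On these data alone, without trifluoromethyl, the size of the methoxy to hydroxy change remains unreadable, with both partners at a limit: the limit of > 10000 nM in this assay, at which 2 of the 4 values shown sit. Also open is whether an amine or a carboxylic acid in place of the hydroxy, or a longer chain on the oxygen, would move the number beyond the scatter.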